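Halogen swap on a shared core, extended to an ether analogue

The source may report more compounds than this note shows. Statements on the series, on what has been measured and on what is new or still open speak of the compounds shown alone.

Compound 1 `CC1=CS[C@@](O)(c2ccc(Cl)cc2)c2noc(=O)n21` and compound 2 `CC1=CS[C@@](O)(c2ccc(Br)cc2)c2noc(=O)n21` share one core and differ only by bromo in place of chloro on an aromatic carbon. In a functional assay (Cavia porcellus) with Rattus norvegicus as the target (on this read-out lower numbers stand for an effect already at smaller amounts and higher numbers for an effect only at larger amounts of compound), compound 1 gives 800 nM, and compound 2 gives 320 nM; the step is a 2.5-fold lower number from compound 1 to compound 2 (0.40 log units; beyond the scatter). Compound 3 `CCCCCCCC/C=C\CCCCCCCCO[C@@]1(c2ccc(Cl)cc2)SC=C(C)n2c1noc2=O` carries a different core, and the difference between the two cores is not broken down here. In this assay compound 3 gives 870 nM, a value within the scatter of that of compound 1, while the values of compound 3 and compound 2 lie further apart.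

Compound 4 `CCCCCCCC/C=C\CCCCCCCCO[C@@]1(c2ccc(Br)cc2)SC=C(C)n2c1noc2=O` has not yet been measured. It differs from compound 3 by bromo in place of chloro on an aromatic carbon, the same change as that from compound 1 to compound 2, at the same place on the ring. Because the step of a 2.5-fold lower number from compound 1 to compound 2 (0.40 log units; beyond the scatter) was seen on the first core, a step of similar size, a 2.5-fold lower number from compound 3 to compound 4 (0.40 log units; beyond the scatter), is expected on the second. On that basis compound 4 is estimated at 350 nM in this assay, with a range from 150 nM to 800 nM expected.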

Compound 4, half-maximal effective concentration: 1260 nM
Compound 4: middle estimate off by 3.6-fold (0.56 log units), on the low side; measured number above the stated range.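

In this assay, the change from 4-chlorophenyl to 4-bromophenyl did not behave alike on the two cores, and the gap between the two steps is larger than the scatter allows: the same change on two cores in this assay, a 2.5-fold lower number (0.40 log units; beyond the scatter) from compound 1 to compound 2 and a 1.4-fold higher number (0.16 log units; within the scatter) from compound 3 to compound 4, 3.6-fold (0.56 log units) apart, beyond the scatter of two such steps. On the second core the swap gives a 1.4-fold higher number from compound 3 to compound 4 (0.16 log units; within the scatter), so the clear step seen on the first core does not recur there. For the compounds shown here, this shows that the step on one core was no reliable guide to the other, but it rests on only two pairs and does not show which part of the difference between the cores is responsible, nor how the change would behave on any further core.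

Going by these compounds, it remains open whether a shorter ether chain, such as ethyl or octyl, would give a step like that on the first core or like that on the second. Also open, on these data alone, is how a fluoro or methoxy group at the same place on the ring would compare on either core.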